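Carboxy for Hydroxymethyl on Two Related Cores

The source may hold more compounds than are shown below. What is called first, only, known or untested is meant among the compounds shown, and "the series" means these compounds.

Compound 1, `Cn1nc(Cc2nnc(SCCCCCCCC(=O)Nc3ccc(Cl)cc3Cl)n2CCCO)c2ccccc2c1=O`, in an assay on 32D cells for inhibition of interleukin-15 (Mus musculus), read by resazurin assay, with stated times of 30 min and 2.5 days, in the presence of a further agent that is not named here (a higher number here means a weaker inhibitor, a lower number a stronger inhibitor), gives > 30000 nM, which is a limit of the assay rather than a number.
Compound 2, `Cn1nc(Cc2nnc(SCCCCCCCC(=O)Nc3ccc(Cl)cc3Cl)n2CCC(=O)O)c2ccccc2c1=O`, in this assay gives > 30000 nM, again a limit of the assay.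
Compound 3, `Cn1c(Cc2nn(CCCO)c(=O)c3ccccc23)nnc1SCC(=O)Nc1ccc(Cl)cc1Cl`, in this assay gives > 30000 nM, also a limit of the assay.

Compound 1 and compound 2 differ in one place: carboxy in place of hydroxymethyl on a saturated chain carbon, two bonds along the chain from an aromatic nitrogen. Because both values are limits, the step that the two limits leave unreadable from compound 1 to compound 2 cannot be read in size or direction. The same holds across the whole set: the limit of > 30000 nM in this assay, at which 3 of the 3 values shown sit, so none of the three compounds shows a measurable inhibition here, and nothing can be said about which is stronger or weaker.

Compound 3 carries a different core from compound 1; the difference between the two cores is not broken down here. Compound 4, `Cn1c(Cc2nn(CCC(=O)O)c(=O)c3ccccc23)nnc1SCC(=O)Nc1ccc(Cl)cc1Cl`, has not yet been measured. It relates to compound 3 exactly as compound 2 relates to compound 1: carboxy in place of hydroxymethyl on a saturated chain carbon, two bonds along the chain from an aromatic nitrogen. The place of the change is described in the same words for both pairs, so this is the same change on another core.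

With compound 3 at the limit and the earlier step unreadable, the expectation for compound 4 is that the step that the limit leaves unreadable from compound 3 to compound 4 leaves it at or near the limit as well. Compound 4 is therefore estimated at 60000 nM, within a range from 20000 nM to 300000 nM, and most likely the assay will once more report only a limit.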

Compound 4, half-maximal inhibitory concentration: > 30000 nM
Compound 4: a limit, no number (the forecaster's own chance of this, stated with the estimate: 85%); the middle value lies beyond the limit too.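

In this assay compound 4 gives > 30000 nM which is a limit of the assay and not a number. Going by these compounds alone, the step from compound 3 to compound 4 therefore cannot be read, in size or in direction, any more than the one from compound 1 to compound 2. The compounds shown leave open whether carboxy or hydroxymethyl matters for inhibition on either core, as the whole set stays at one limit: the limit of > 30000 nM in this assay, at which 4 of the 4 values shown sit.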